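This account rests on a few compounds, and the source may have more. Where it says the series, first, only, none or still open, it means among the compounds named here.

Measured in a functional assay on MCF7 cells (Homo sapiens) for cytotoxicity, read by MTT assay, with a stated time of 72 h; on this read-out lower numbers stand for stronger inhibition and higher numbers for weaker inhibition:

- compound 1 `CNC(=O)c1cc(Oc2ccc(NC(=O)c3nccc(-c4ccc(OC)cc4)n3)cc2)ccn1`: 35200 nM
- compound 2 `CNC(=O)c1cc(Oc2ccc(NC(=O)c3cc(-c4ccc(F)cc4)ncn3)cc2F)ccn1`: > 100000 nM, a limit of the assay, not a number
- compound 3 `CNC(=O)c1cc(Oc2ccc(NC(=O)c3cc(-c4ccc(Cl)cc4)ncn3)cc2)ccn1`: > 100000 nM, likewise a limit

Compound 2 stands at the upper boundary of what this assay reports: its value is a limit only. The same holds for compound 3, so two of the three values shown sit at one boundary, (the limit of > 100000 nM in this assay, at which 2 of the 3 values shown sit). Only compound 1 gives a number, and it lies far toward the weak end of the scale. Within the data shown here, no pair of measured compounds differs in a single place, so no measured step is at hand.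

Compound 4 `CNC(=O)c1cc(Oc2ccc(NC(=O)c3cc(-c4ccc(OC)cc4)ncn3)cc2F)ccn1` is the next compound to be run in this assay. Set beside compound 2, the change is methoxy in place of fluoro on an aromatic carbon. Among the measured compounds shown here, compound 1 carries the same methoxyphenyl group on a differently arranged core and reaches a number, so a small shift toward stronger inhibition is conceivable, but the two limits in hand give no step on which to size it. The expectation is a step from compound 2 to compound 4 of an at least 1.1-fold lower number from compound 2 to compound 4 (0.04 log units; that floor lies within the scatter), close to or within the scatter, with a fair chance that compound 4 again returns only a limit. For compound 4 the estimate in this assay is 90000 nM, in the range 30000 nM to 300000 nM.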

Compound 4, half-maximal inhibitory concentration: 46200 nM
Compound 4: middle estimate off by 1.9-fold (0.29 log units), on the high side; the measured number falls inside the stated range.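

In this assay, among these compounds, the change from 4-fluorophenyl to 4-methoxyphenyl gives the only readable step, an at least 2.1-fold lower number from compound 2 to compound 4 (0.33 log units; beyond the scatter) and compound 4 gives 46200 nM as a true number. This shows that the position para to a large group responds to a single substituent change, enough to bring the read-out off the assay boundary. Going by these compounds, compound 2 has only a limit of > 100000 nM so the full size of the step stays unknown, and the printed figure is a floor: the limit of > 100000 nM in this assay, at which 2 of the 4 values shown sit.

On these data alone, whether an amine, a hydroxyl or a longer chain such as ethoxy on the same aromatic carbon would move the number further toward stronger inhibition remains open, as does whether any substituent here can give more than weak cytotoxicity. Also open, as far as these compounds go, is how the arrangement of the core, the chloro group of compound 3 and the fluoro group on the central ring each contribute, since compound 1 and compound 3 differ from the others in more than one place and their steps cannot be read.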